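The compounds below may be only part of what the source reports. "The series", "measured", "known", "first", "only" and "open" are said of these compounds alone.

Compound 2 `COc1cc(-c2nnc3n2NC(c2ccco2)C(C(=O)c2cccc(Br)c2)S3)cc(OC)c1OC` is known in a functional assay on HepG2 cells (Homo sapiens) for cytotoxicity, read by MTT assay, with a stated time of 48 h (a higher number here means a weaker inhibitor, a lower number a stronger inhibitor), only as a limit, > 100000 nM. Compound 2 thus stands at the limit of > 100000 nM in this assay, at which 1 of the 2 values shown sits, with no fixed number behind it. Compound 1 `COc1cc(-c2nnc3n2NC(c2cccs2)C(C(=O)c2ccc(F)cc2)S3)cc(OC)c1OC` gives 54200 nM in this assay. Compound 3 `COc1cc(-c2nnc3n2NC(c2ccco2)C(C(=O)c2ccc(-c4ccccc4)cc2)S3)cc(OC)c1OC` carries 4-phenylphenyl in place of 3-bromophenyl on a carbonyl carbon. Among the compounds with values here, no measured pair covers this change, so the size of an at least 1.1-fold lower number from compound 2 to compound 3 (0.04 log units; that floor lies within the scatter) can only be expected, and no shift beyond the scatter is assumed in either direction from the limit. For compound 3 the expected value in this assay is 90000 nM, within 30000 nM to 250000 nM, with a fair chance that again only a limit is reported.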

Compound 3, half-maximal inhibitory concentration: > 100000 nM
Compound 3: a limit, no number; the forecaster's own chance of this, stated with the estimate: 55%; middle value at least 1.1-fold (0.04 log units) from the limit.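

Compound 2 and compound 3 both stand only as limits, not numbers, so no step between them can be read: the limit of > 100000 nM in this assay, at which 2 of the 3 values shown sit.

Going by these compounds, whether 4-phenylphenyl in place of 3-bromophenyl on a carbonyl carbon shifts the value at all, and in which direction, remains open.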